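The source may hold more compounds than are shown below. What is called first, only, known or untested is meant among the compounds shown, and "the series" means these compounds.

Measured compounds:
compound 1 `N#Cc1cnc(NCc2cnccc2C(F)(F)F)cc1N[C@H]1CC[C@@H](O)CC1` — 4500 nM
compound 2 `CO[C@H]1CC[C@@H](Nc2cc(NCc3cnccc3C(F)(F)F)ncc2C#N)CC1` — 5000 nM
compound 3 `CO[C@H]1CC[C@@H](CNc2cc(NCc3cnccc3C(F)(F)F)ncc2C#N)CC1` — 5000 nM

In an assay on isolated protein for inhibition of protein kinase C delta type (Homo sapiens), read by TR-FRET, with a stated time of 2 h (on this read-out lower numbers stand for stronger inhibition and higher numbers for weaker inhibition), compound 3 gives 5000 nM. This places compound 3 level with compound 2, the two together giving the highest numbers of the three; the step of no change at the digits printed from compound 2 to compound 3 (within the scatter) carries no change at the digits reported, and the step of a 1.1-fold higher number from compound 1 to compound 3 (0.05 log units; within the scatter) is also within the scatter, so no one of the three can be set apart from the others.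

Compound 4 `N#Cc1cnc(NCc2cnccc2C(F)(F)F)cc1NCC1CCOCC1` differs from compound 3 by oxan-4-yl in place of 4-methoxycyclohexyl on a saturated chain carbon bound to a nitrogen on an aromatic ring. Within the data shown here, two measured steps touch this part of the molecule: a 1.1-fold higher number from compound 1 to compound 2 (0.05 log units; within the scatter) and no change at the digits printed from compound 2 to compound 3 (within the scatter), both within the scatter. Neither of them covers the exchange of a carbon ring for a ring with one hetero atom, nor the loss of the methoxy group, so the new change is only partly anchored. Since every change so far in this region left the read-out unmoved, compound 4 is expected to show no step beyond the scatter, and the estimated step of no change at the digits printed from compound 3 to compound 4 (within the scatter) reflects this. Compound 4 is therefore estimated at 5000 nM, with a range from 2000 nM to 12000 nM.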

Compound 4, half-maximal inhibitory concentration: 5000 nM
Estimate against measurement, compound 4: no gap at the digits printed; measured number inside the range.
By their numbers in this assay, from the lowest: compounds 1, 2, 3 and 4 (each within the scatter of the next).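

In this assay, replacing 4-methoxycyclohexyl with oxan-4-yl on a saturated chain carbon bound to a nitrogen on an aromatic ring gives no change at the digits printed from compound 3 to compound 4 (within the scatter) even though the group goes from 8 heavy atoms to 6, its ring of carbon only becomes a ring with 1 hetero atom, and its 2 defined stereocentres are lost. Among these compounds, this extends what the earlier compounds showed at this position, as the wider exchange of 4-methoxycyclohexyl for (oxan-4-yl)methyl gives no change at the digits printed from compound 2 to compound 4 (within the scatter) and that of 4-hydroxycyclohexyl for (oxan-4-yl)methyl gives a 1.1-fold higher number from compound 1 to compound 4 (0.05 log units; within the scatter) in the same assay. No available evidence bears on why these exchanges leave the number unmoved.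

Going by these compounds, all the groups compared here at this position are saturated six-membered rings carrying oxygen, so it remains open whether a basic amine such as piperidin-4-yl, a carboxylic acid or a longer open chain would give a different number in this assay. The shared core is the same in every compound shown, so what its nitrile or trifluoromethyl group contributes also remains open.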